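Second methoxy on the aryl ring: expectation before measurement

The source may report more compounds than this note shows. Statements on the series, on what has been measured and on what is new or still open speak of the compounds shown alone.

Working notes on the series around compound 1 `CCOc1cccc2cc(-c3ccc(OC)cc3)c(=O)oc12`. In a functional assay on CHO cells for antagonist activity at adenosine receptor A2b (Homo sapiens), read by cAMP accumulation (on this read-out higher numbers stand for weaker inhibition and lower numbers for stronger inhibition), compound 1 reaches only the assay limit, > 30000 nM. Compound 2 `CCOc1cccc2cc(-c3ccc([N+](=O)[O-])cc3)c(=O)oc12` likewise sits at the limit in this assay, > 30000 nM. Going by the values given here, the one measured step is unreadable, a step that the two limits leave unreadable from compound 1 to compound 2, since both values sit at the limit of > 30000 nM in this assay, at which 2 of the 2 values shown sit. Compound 3 `CCOc1cccc2cc(-c3ccc(OC)c(OC)c3)c(=O)oc12` differs from compound 1 by methoxy in place of hydrogen on an aromatic carbon. Among the compounds with values here, no measured step bears on this change, and the two limits give no sign of any readable shift. The estimate for compound 3 in this assay is 30000 nM, with a range from 8000 nM to 100000 nM. The expected step, a number no higher from compound 1 to compound 3 (the limit leaves the size open), is none beyond the scatter.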

Compound 3, half-maximal inhibitory concentration: > 30000 nM
Compound 3: no number, only a limit; the forecaster's own chance of this, stated with the estimate: 80%; the middle value sits exactly at the limit.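

No new step can be read between compound 1 and compound 3 in this assay, because both stop at the assay limit: the limit of > 30000 nM in this assay, at which 3 of the 3 values shown sit.

The compounds shown leave open whether a second methoxy changes inhibition at all.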